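This account rests on a few compounds, and the source may have more. Where it says the series, first, only, none or still open, it means among the compounds named here.

Of the compounds shown here, three sharing one core have been measured in a physicochemical assay for solubility, in phosphate buffer, with a stated time of 18 h; on this read-out higher numbers stand for higher solubility and lower numbers for lower solubility. Compound 1 `N#Cc1c(N)nc2nc(C3CCCC3)ncc2c1N` gives 89000 nM, and compound 2 `CC(C)Cc1ncc2c(N)c(C#N)c(N)nc2n1` gives 268000 nM. Compound 3 `CCCCc1nc(C(C)(C)C)nc2nc(N)c(C#N)c(N)c12` gives 6000 nM, the lowest of the three numbers. Compound 1 is the closer of the other two on this scale, and compound 2 is the furthest away.

Compound 4 `CC(C)(C)c1nc(-c2ccsc2)c2c(N)c(C#N)c(N)nc2n1` is the next to be measured in this assay. It differs from compound 3 in one place, with thiophen-3-yl in place of butyl on an aromatic carbon. The tert-butyl group stays in both.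

For the measured compounds named here, only one measured step changes a single place, a 3.0-fold higher number from compound 1 to compound 2 (0.48 log units; beyond the scatter). That step swaps cyclopentyl for isobutyl, so it involves neither group at issue here and offers only a rough sense of how far one swap on an aromatic carbon can move the number. Going by the values given here, no measurement yet shows how thiophen-3-yl behaves. The best starting point is therefore compound 3 with its 6000 nM, and the uncertainty should be at least as wide as the modest step measured so far.

No step beyond the scatter is expected, and the estimate means a 1.2-fold lower number from compound 3 to compound 4 (0.08 log units; within the scatter). The estimated value for compound 4 is 5000 nM, with an expected range from 1500 nM to 20000 nM.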

Compound 4, solubility: 40000 nM
The estimate for compound 4 lay 8.0-fold (0.90 log units) below the measured number, outside the stated range (above it).
By their numbers in this assay, from the lowest: compound 3; then compound 4; then compound 1; then compound 2.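

In this assay, the carbon next to the ring nitrogen and meta to the tert-butyl group proves to be a place where the substituent matters: thiophen-3-yl in place of butyl gives a 6.7-fold higher number from compound 3 to compound 4 (0.82 log units; beyond the scatter), a step beyond the usual scatter. For the compounds shown here, the only earlier single change, a 3.0-fold higher number from compound 1 to compound 2 (0.48 log units; beyond the scatter), involved neither of these groups, so this is the first direct view of what happens when an open chain on this carbon gives way to a five-membered aromatic ring holding sulfur. This one pair, with the tert-butyl group kept in both compounds, ties the ring to a higher number rather than a lower one, but nothing available explains the rise.

On these data alone, it stays open whether the rise belongs to the aromatic ring in general or to thiophen-3-yl in particular, a question that phenyl or saturated cyclopentyl on this carbon would help to settle. Also open, as far as these compounds go, is whether the same swap moves the number as far with isobutyl in place of the tert-butyl group, and how an amine or a carboxylic acid on this carbon would compare.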